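The source may hold more compounds than are shown below. What is called first, only, known or untested is meant among the compounds shown, and "the series" means these compounds.

Going by the values given here, in a physicochemical assay for solubility, at pH 1.2 (a higher number here means a more soluble compound, a lower number a less soluble compound), compound 2 `C[C@@H](Cn1c(=O)[nH]/c(=N\c2ccc(Oc3ccnc(F)c3)cc2)n(Cc2ccc(Cl)cc2)c1=O)C(=O)O` gives 2.2 ug/mL, the lower of the two numbers so far, while compound 1 `C[C@@H](Cn1c(=O)[nH]/c(=N\c2ccc(Oc3ccccn3)cc2)n(Cc2ccc(Cl)cc2)c1=O)C(=O)O` gives 31.5 ug/mL. Compound 3 `C[C@@H](Cn1c(=O)[nH]/c(=N\c2ccc(Oc3ccsn3)cc2)n(Cc2ccc(Cl)cc2)c1=O)C(=O)O` keeps the shared core but carries 1,2-thiazol-3-yl in place of 2-fluoropyridin-4-yl on an oxygen on an aromatic ring. Among the compounds with values here, the only measured step at this place is a 14-fold lower number from compound 1 to compound 2 (1.16 log units; beyond the scatter), a large one, so another large move in this assay is possible. Neither measured compound has a five-membered aromatic ring, which leaves the guide indirect. A moderate rise is expected, an estimated 3.2-fold higher number from compound 2 to compound 3 (0.50 log units; beyond the scatter). Compound 3 is estimated at 7 ug/mL, with an expected range of 2 ug/mL to 25 ug/mL.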

Compound 3, solubility: 0.8 ug/mL
The estimate for compound 3 lay 8.8-fold (0.94 log units) above the measured number; measured number below the stated range.
By their numbers in this assay, from the lowest: compound 3; then compound 2; then compound 1.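

In this assay the five-membered 1,2-thiazol-3-yl sits lower still than 2-fluoropyridin-4-yl, with a 2.8-fold lower number from compound 2 to compound 3 (0.44 log units; beyond the scatter) on the same oxygen, so leaving the six-membered ring does not bring the number back up. Going by these compounds alone, measured from pyridin-2-yl, the change is a 39-fold lower number from compound 1 to compound 3 (1.60 log units; beyond the scatter) and is the widest step at this place so far, leaving pyridin-2-yl the highest of the three groups. Nothing available explains these differences. Still open, as far as these compounds go, is how a plain phenyl or a pyridine ring bearing an amine would read on this oxygen, and whether another five-membered ring, such as 1,3-thiazol-2-yl, would fall as low.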